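Fluoroethoxy to fluorobenzyloxy on the triazole-quinuclidine series

A few compounds are considered here, and "the series" means these few. Any claim that something is new, unique, unknown or untested is made for them only; others in the source may bear on it.

Compound 2 `FCCOc1cccc(-c2cn(C3CN4CCC3CC4)nn2)c1` is the starting point. Within the data shown here, in an assay on HEK293 cells for displacement of a labelled ligand from Neuronal acetylcholine receptor; alpha3/beta4 (Homo sapiens), read by scintillation counting, with a stated time of 120 min (a lower number here means a stronger inhibitor, a higher number a weaker inhibitor), compound 2 gives 20.9 nM, the highest of the three numbers so far. Among the measured compounds shown here, compound 1 `FCCOc1cccc(-c2cn([C@@H]3CN4CCC3CC4)nn2)c1` gives 11.8 nM, and the step of a 1.8-fold higher number from compound 1 to compound 2 (0.25 log units; within the scatter) is the only single-place comparison available; it rests on the fact that one of compounds 1 and 2 is drawn with a defined configuration and the other without, at the place where they differ and carries no information about the ether chain. For the measured compounds named here, compound 3 `Fc1ccc(-c2cn([C@@H]3CN4CCC3CC4)nn2)cc1` gives 3.09 nM; compound 3 differs from compound 2 in more than one place, so the two values show only that compound 3 sits well below compound 2.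

Compound 4 `Fc1ccc(COc2cccc(-c3cn(C4CN5CCC4CC5)nn3)c2)cc1` carries the change (4-fluorophenyl in place of fluoromethyl on a saturated chain carbon bound to an oxygen on an aromatic ring). Going by the values given here, no measured step touches this part of the molecule, so the direction of the effect cannot be read from the series; a larger group enters where a small one stood, and the honest expectation is a step of unknown sign, with the middle placed near the parent.

The step of a 1.4-fold higher number from compound 2 to compound 4 (0.16 log units; within the scatter) is expected to be small relative to the uncertainty. Compound 4 is estimated at 30 nM, in the range 7 nM to 130 nM.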

Compound 4, inhibition constant: 13.9 nM
Beside the measured number, compound 4's estimate is 2.2-fold (0.33 log units) above it; the measured number falls inside the stated range.
By their numbers in this assay, from the lowest: compound 3; then compounds 1, 4 and 2 (each within the scatter of the next).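

Among these compounds, this is the first measured step at this position: in this assay, the change gives a 1.5-fold lower number from compound 2 to compound 4 (0.18 log units; within the scatter). Replacing fluoromethyl with 4-fluorophenyl on a saturated chain carbon bound to an oxygen on an aromatic ring therefore adds a six-membered aromatic ring of carbon only, with no step beyond the scatter, and compound 2 and compound 4 are both drawn without a configuration at the saturated ring carbon. Nothing on record accounts for the size of this step.

Open, on these data alone, is whether an amine, a carboxylic acid or a longer chain at this same place would also stay within the scatter of compound 2, since one aromatic replacement gives no trend. Also open, as far as these compounds go, is how compound 4 would read with the saturated ring carbon drawn S, as it is in compound 1.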